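Swapping trifluoromethyl for methoxymethyl on the aryl ring

This account rests on a few compounds, and the source may have more. Where it says the series, first, only, none or still open, it means among the compounds named here.

Compound 1 `O=C(O)CCCSCCN1C(=O)OC[C@@H]1/C=C/[C@@H](O)Cc1cccc(C(F)(F)F)c1` gives 1600 nM in an assay on CHO cells for displacement of a labelled ligand from prostaglandin E2 receptor EP3 subtype (Mus musculus), read by scintillation counting, with a stated time of 60 min; on this read-out higher numbers stand for weaker inhibition and lower numbers for stronger inhibition.
Compound 2 `CCCc1cccc(C[C@H](O)/C=C/[C@H]2CSC(=O)N2CCSCCCC(=O)O)c1` gives 1200 nM.
Compound 3 `CCc1cccc(C[C@H](O)/C=C/[C@H]2CSC(=O)N2CCSCCCC(=O)O)c1` gives 65 nM.

Compound 1 stands at the top end of these three numbers. Its gap to compound 2 lies within the usual scatter, while compound 3 sits far below it, at a much lower number.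

Compound 4 `COCc1cccc(C[C@H](O)/C=C/[C@H]2COC(=O)N2CCSCCCC(=O)O)c1` is not yet measured. It differs from compound 1 in one place: methoxymethyl in place of trifluoromethyl on an aromatic carbon.

For the measured compounds named here, no measured step concerns this exchange. Going by the values given here, the only single-place step, an 18-fold lower number from compound 2 to compound 3 (1.27 log units; beyond the scatter), changes a different substituent on the same aromatic ring. It shows that a small alteration there can move the number a long way, but it says nothing about the direction an exchange of trifluoromethyl for methoxymethyl would take. The expectation for compound 4 is therefore an open one: a step of roughly a 1.6-fold lower number from compound 1 to compound 4 (0.20 log units; within the scatter) is estimated, with a wide margin in both directions. Compound 4 is expected to give 1000 nM, between 150 nM and 6000 nM.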

Compound 4, inhibition constant: > 10000 nM
Compound 4: a limit, no number; the forecaster's own chance of this, stated with the estimate: 10%; at least 10-fold (1.00 log units) between middle value and limit.
By their numbers in this assay, from the lowest: compound 3; then compounds 2 and 1 (each within the scatter of the next). At a limit, above all of these: compound 4.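

On the aromatic ring of compound 1, methoxymethyl in place of trifluoromethyl gives an at least 6.2-fold higher number from compound 1 to compound 4 (0.79 log units; beyond the scatter) in this assay. Compound 4 gives a limit of the assay and not a number: the limit of > 10000 nM in this assay, at which 1 of the 4 values shown sits. For the compounds shown here, the only earlier step on this ring, an 18-fold lower number from compound 2 to compound 3 (1.27 log units; beyond the scatter), ran towards a lower number, so this result adds a clear change in the opposite direction and shows that this position does not accept every small group equally on the core of compound 1.

The compounds shown leave open how far the true value of compound 4 lies beyond its limit, and whether the oxygen of methoxymethyl or the absence of trifluoromethyl accounts for the change. They also leave open how a methoxy group or a chlorine atom would read at this place.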